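Series notes: variation of the sulfur-linked aryl arm

This account rests on a few compounds, and the source may have more. Where it says the series, first, only, none or still open, it means among the compounds named here.

Measured so far in an assay for binding affinity to leukotriene B4 receptor 1 (Homo sapiens); a higher number here means a weaker inhibitor, a lower number a stronger inhibitor:
- compound 1 `COc1ccc(CCCCCCCCOc2ccc(C[S+]([O-])c3ccccc3)nc2/C=C/C(=O)O)cc1`; compound 1 gives 37 nM
- compound 2 `COc1ccc(CCCCCCCCOc2ccc(C[S+]([O-])c3cccc(N)c3)nc2/C=C/C(=O)O)cc1`; compound 2 gives 4.7 nM
- compound 3 `COc1ccc(CCCCCCCCOc2ccc(CSc3cccc(OC)c3)nc2/C=C/C(=O)O)cc1`; compound 3 gives 192 nM

Compound 3 carries the highest number of the three; compound 1 lies nearest to it and compound 2 furthest. Compound 4 `COc1ccc(CCCCCCCCOc2ccc(C[S+]([O-])c3cccc(N(C)C)c3)nc2/C=C/C(=O)O)cc1` is not yet measured. Going from compound 3 to compound 4 the change is a group of 11 heavy atoms (8 carbon, 1 nitrogen, 1 oxygen, 1 sulfur; one six-membered aromatic ring of carbon only) in place of a group of 9 heavy atoms (7 carbon, 1 oxygen, 1 sulfur; one six-membered aromatic ring of carbon only), on a saturated chain carbon bound to an aromatic carbon; what enters is an aryl sulfoxide carrying a dimethylamino group, so compound 4 differs from compound 3 both at the sulfur and in the ring substituent. Among the compounds with values here, two measured steps bear on this. Replacing the unsubstituted phenyl sulfoxide arm with the (3-methoxyphenyl)sulfanyl arm gave a 5.2-fold higher number from compound 1 to compound 3 (0.72 log units; beyond the scatter), and the same replacement starting from the amino-bearing sulfoxide gave a 41-fold higher number from compound 2 to compound 3 (1.61 log units; beyond the scatter); within the sulfoxide pair, a 7.9-fold lower number from compound 1 to compound 2 (0.90 log units; beyond the scatter). Run in reverse, a drop in this assay is expected for compound 4, probably of a size between those two steps; no measured compound carries a dimethylamino group, so the exact size is open. Compound 4 is estimated at 9 nM (range 3 nM to 30 nM), which means an expected step of a 21-fold lower number from compound 3 to compound 4 (1.33 log units; beyond the scatter).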

Compound 4, inhibition constant: 245 nM
For compound 4 the middle estimate is 27-fold (1.43 log units) below the measured one, and the stated range ends below it.
By their numbers in this assay, from the lowest: compound 2; then compound 1; then compounds 3 and 4 (each within the scatter of the next).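

In this assay the gain from a nitrogen substituent on the aryl sulfoxide arm proves highly specific to amino: dimethylamino in place of amino gives a 52-fold higher number from compound 2 to compound 4 (1.72 log units; beyond the scatter) and removes that gain entirely. Dimethylamino in place of hydrogen gives a 6.6-fold higher number from compound 1 to compound 4 (0.82 log units; beyond the scatter) and so moves the number the opposite way from amino, which means a nitrogen-bearing substituent at this ring carbon does not by itself lower the number in these compounds. The step of a 1.3-fold higher number from compound 3 to compound 4 (0.11 log units; within the scatter) also shows that the aryl sulfoxide arm carrying dimethylamino offers no measurable advantage over the (3-methoxyphenyl)sulfanyl arm, and no available evidence accounts for the loss on going from amino to dimethylamino.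

From the compounds shown here alone, whether a single methyl on the nitrogen, as in a methylamino group, already costs this much remains open, as does the outcome with an acetamide or a hydroxyl group in the same place. Going by these compounds, what the sulfur alone contributes also stays open: the steps to compound 3 change the ring substituent together with the sulfur, and only a sulfide and a sulfoxide sharing one ring substituent, such as the 3-methoxyphenyl pair, would separate the two.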